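Heteroaryl exchange from compound 2 to compound 3

The source may report more compounds than this note shows. Statements on the series, on what has been measured and on what is new or still open speak of the compounds shown alone.

Measured in a functional assay for activation of Alpha-1A adrenergic receptor (Homo sapiens), read by calcium flux; on this read-out lower numbers stand for an effect already at smaller amounts and higher numbers for an effect only at larger amounts of compound:
compound 1 `Cc1nc(-c2ccccc2NCC2=NCCN2)cs1` gives 4.47 nM
compound 2 `c1csc(-c2ccccc2NCC2=NCCN2)c1` gives 2.24 nM

Among the compounds with values here, compound 2 and compound 1 lie within the scatter of each other, the only measured step being a 2.0-fold lower number from compound 1 to compound 2 (0.30 log units; within the scatter). Compound 3 `Cc1cc(-c2ccccc2NCC2=NCCN2)on1` differs from compound 2 by 3-methyl-1,2-oxazol-5-yl in place of thiophen-2-yl on an aromatic carbon. Within the data shown here, the one step that bears on this, a 2.0-fold lower number from compound 1 to compound 2 (0.30 log units; within the scatter), is likewise an exchange of one five-membered aromatic ring for another and stays within the scatter, so no change beyond the scatter is expected in this assay for compound 3. The expected step is estimated as a 1.8-fold higher number from compound 2 to compound 3 (0.25 log units; within the scatter). Compound 3 is expected at 4 nM, within a range of 1.5 nM to 12 nM.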

Compound 3, half-maximal effective concentration: 38.9 nM
For compound 3 the middle estimate is 9.7-fold (0.99 log units) below the measured one, and the stated range ends below it.
By their numbers in this assay, from the lowest: compounds 2 and 1 (each within the scatter of the next); then compound 3.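

In this assay the position on the aromatic carbon does not treat all five-membered aromatic rings alike: 3-methyl-1,2-oxazol-5-yl in place of thiophen-2-yl gives a 17-fold higher number from compound 2 to compound 3 (1.24 log units; beyond the scatter), and in place of 2-methyl-1,3-thiazol-4-yl it gives an 8.7-fold higher number from compound 1 to compound 3 (0.94 log units; beyond the scatter). Within the data shown here, the earlier ring exchange stayed within the scatter, so these steps are the first beyond it at this position. No evidence is available to account for them.

The compounds shown leave open whether the methyl group or the 1,2-oxazole ring carries these steps. Going by these compounds, how a phenyl ring or an amine at this position would read also remains open.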